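The source may report more compounds than this note shows. Statements on the series, on what has been measured and on what is new or still open speak of the compounds shown alone.

Compound 1 `Cc1ccc(S(=O)(=O)N[C@@H](CC(=O)NC(C)(C)C)C(=O)NCCNC(=O)c2cc(Cl)ccn2)cc1` reads > 11000 nM as a limit
Compound 2 `Cc1ccc(S(=O)(=O)N[C@@H](CC(=O)NC(C)(C)C)C(=O)NCCNC(=O)c2cc(Cl)ccc2Cl)cc1` reads > 11000 nM as a limit
Compound 3 `C#Cc1cccc(C(=O)NCCNC(=O)[C@H](CC(=O)NC(C)(C)C)NS(=O)(=O)c2ccc(C)cc2)c1` reads > 11000 nM as a limit

All three readings come from an ADME assay on HepG2 cells (Homo sapiens) for cytotoxicity (on this read-out lower numbers stand for an effect already at smaller amounts and higher numbers for an effect only at larger amounts of compound), and each is a limit of the assay, not a number. Compound 3 therefore has no exact value to start from. Compound 4 `Cc1ccc(S(=O)(=O)N[C@@H](CC(=O)NC(C)(C)C)C(=O)NCCNC(=O)c2ccccc2O)cc1` carries 2-hydroxyphenyl in place of 3-ethynylphenyl on a carbonyl carbon, counted as 2-hydroxyphenyl in place of 3-ethynylphenyl on a carbonyl carbon in full.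

The same place changes in a step that the two limits leave unreadable from compound 1 to compound 2, in a step that the two limits leave unreadable from compound 1 to compound 3 and in a step that the two limits leave unreadable from compound 2 to compound 3, so these steps bear on the change, yet none has a readable size. Starting from compound 3, no step beyond the scatter is expected, in either direction, because of the limit of > 11000 nM in this assay, at which 3 of the 3 values shown sit, here. The expected change is a step that the limit leaves unreadable from compound 3 to compound 4 in this case. Compound 4 is estimated at 15000 nM, with an expected range of 8000 nM to 40000 nM overall.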

Compound 4, half-maximal effective concentration: > 11000 nM
Compound 4: a limit, no number (the forecaster's own chance of this, stated with the estimate: 90%); the middle value lies beyond the limit too.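

Compound 4, like compound 1, compound 2 and compound 3, gives a limit and not a number, so no step among them can be read: the limit of > 11000 nM in this assay, at which 4 of the 4 values shown sit.

On these data alone, whether changing the group on the carbonyl carbon alters this read-out at all stays open.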